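A few compounds are considered here, and "the series" means these few. Any claim that something is new, unique, unknown or untested is made for them only; others in the source may bear on it.

Among the compounds with values here, in a functional assay on NCI-H1299 cells (Homo sapiens) for inhibition, read by CCK-8 assay, with a stated time of 72 h, tested at 1 uM (on this read-out lower numbers stand for less inhibition of growth and higher numbers for more inhibition of growth at the one concentration tested), compound 1 (`CN(C)C(=O)c1cc2cnc(Nc3ccc(NC(=O)C4(C(=O)Nc5ccc(F)cc5)CC4)cc3)nc2n1C1CCCC1`) gives 93.3% and compound 2 (`CN(C)C(=O)c1cc2cnc(Nc3ccc(NC(=O)C4(C(=O)Nc5cccc(O)c5)CC4)cc3)nc2n1C1CCCC1`) gives 77.5% as the lower of the two numbers so far. Compound 3 (`CN(C)C(=O)c1cc2cnc(Nc3ccc(NC(=O)C4(C(=O)Nc5cccc(Cl)c5)CC4)cc3)nc2n1C1CCCC1`) keeps the shared core of compound 2 and differs in one substituent: chloro in place of hydroxy on an aromatic carbon in short, chloro in place of hydroxy on an aromatic carbon, meta to a large group.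

Within the data shown here, one measured step bears on this change. It is a number 15.8 percentage points lower from compound 1 to compound 2 (beyond the scatter) and it came with 3-hydroxyphenyl in place of 4-fluorophenyl on an amide-type nitrogen. Read in reverse, this single pair hints that leaving the hydroxy group may raise the number. Among the measured compounds shown here, the support is thin, since the comparison partner there is 4-fluorophenyl and not 3-chlorophenyl, and no chloro compound has been measured yet.

A rise smaller than that modest step, or close to it, is therefore expected in this assay for the new compound. The expected change is a number 10.5 percentage points higher from compound 2 to compound 3 (beyond the scatter) on this estimate. For compound 3 the estimated value is 88% with an expected range from 74% to 98% in this read-out.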

Compound 3, percent growth inhibition at one concentration: 47.9%
Estimate against measurement, compound 3: 40.1 percentage points above; the measured number lies below the stated range.
By their numbers in this assay, from the lowest: compound 3; then compound 2; then compound 1.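

In this assay chloro in place of hydroxy on this aromatic carbon, meta to a large group, gives a number 29.6 percentage points lower from compound 2 to compound 3 (beyond the scatter) and so hydroxy at this place is not the drawback that the earlier step, read alone, seemed to suggest. 3-chlorophenyl in place of 4-fluorophenyl on the amide-type nitrogen gives a number 45.4 percentage points lower from compound 1 to compound 3 (beyond the scatter) and this large step shows that growth inhibition depends strongly on what this ring carries, although the halogen and its place both differ in that pair and their shares cannot be separated. The data at hand give no measured basis for explaining the fall with chloro.

Open, from the compounds shown here alone, is whether the loss belongs to chloro itself or extends to other groups at this place, which a 3-fluorophenyl, 3-methoxyphenyl or 3-aminophenyl ring would help to settle. Also open, going by these compounds, is whether the place or the halogen carries the difference from compound 1, a question that 4-chlorophenyl and 3-fluorophenyl rings on the same amide-type nitrogen would address directly.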